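Compound 3 to compound 4: replacing cyclohexyl

The compounds below may be only part of what the source reports. "The series", "measured", "known", "first", "only" and "open" are said of these compounds alone.

Values so far in a physicochemical assay for solubility, with a stated time of 24 h, tested at 30 mg/mL; on this read-out lower numbers stand for lower solubility and higher numbers for higher solubility:
- compound 1 `CC[C@H](Nc1c(NCCCCCC(=O)NO)c(=O)c1=O)c1ccccc1` gives 57000000 nM
- compound 2 `Cc1ccc([C@H](C)Nc2c(NCCCCCC(=O)NO)c(=O)c2=O)cc1` gives 5600000 nM
- compound 3 `O=C(CCCCCNc1c(NC2CCCCC2)c(=O)c1=O)NO` gives 8700000 nM

In this assay, compound 3 at 8700000 nM lies within the scatter of compound 2 at 5600000 nM. The gap from compound 3 to compound 1 at 57000000 nM is beyond the scatter, and compound 1 has the highest number of the three.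

Compound 4 `COc1ccc(Nc2c(NCCCCCC(=O)NO)c(=O)c2=O)cc1` has 4-methoxyphenyl in place of cyclohexyl on a nitrogen on an aromatic ring. Within the data shown here, compound 1 and compound 2 also hold an aromatic ring, but neither carries 4-methoxyphenyl, and no measured pair isolates this change.

A modest step to a lower number is expected in this assay, slightly beyond the scatter. This expectation leans on compound 2 at 5600000 nM, while compound 1 at 57000000 nM goes against it, so the range is kept wide. The estimated step is a 2.5-fold lower number from compound 3 to compound 4 (0.40 log units; beyond the scatter). For compound 4 the estimated value is 3500000 nM, with an expected range of 900000 nM to 13000000 nM.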

Compound 4, solubility: 300000 nM
Compound 4: middle estimate off by 12-fold (1.07 log units), on the high side, and the stated range ends above it.
By their numbers in this assay, from the lowest: compound 4; then compounds 2 and 3 (each within the scatter of the next); then compound 1.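

In this assay, among these compounds, the place on a nitrogen on an aromatic ring proves sensitive: 4-methoxyphenyl in place of cyclohexyl gives a 29-fold lower number from compound 3 to compound 4 (1.46 log units; beyond the scatter) as a large step, and this is the first change that can be read at a single place. With compound 4 at 300000 nM it becomes clear that exchanging a six-membered non-aromatic ring of carbon only for a six-membered aromatic ring of carbon only, with one hydrogen-bond acceptor entering, can move the read-out well beyond the scatter. No measurement at hand bears on what lies behind this step and this single pair gives its size at one place only.

From the compounds shown here alone, whether the step belongs to the aromatic ring itself or to its methoxy group stays open, and a plain phenyl on the same nitrogen would separate the two. Also open, going by these compounds, is how a tertiary amine or a carboxylic acid carried on that ring would read in this assay against the 4-methoxyphenyl of compound 4.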